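Changing the ring on the side chain of a weak cytotoxic core

The source may hold more compounds than are shown below. What is called first, only, known or untested is meant among the compounds shown, and "the series" means these compounds.

Compound 1 `COc1cccc([C@H](O)[C@H]2CO[C@H](c3ccc(OC)c(OC)c3)[C@@H](C/C=C/c3ccc(OC)c(OC)c3)C2)c1`: 21200 nM
Compound 2 `Cc1ccc(/C=C/C[C@H]2C[C@@H]([C@@H](O)c3ccccc3)CO[C@@H]2c2ccccc2)cc1C`: 10000 nM

In a functional assay on HeLa cells (Homo sapiens) for cytotoxicity, read by WST assay, with a stated time of 48 h (on this read-out higher numbers stand for weaker inhibition and lower numbers for stronger inhibition), compound 2 gives 10000 nM, the lower of the two numbers, and compound 1 gives 21200 nM, a gap beyond the usual scatter. Compound 3 `COc1ccccc1/C=C/C[C@H]1C[C@@H]([C@@H](O)c2ccccc2)CO[C@@H]1c1ccccc1` keeps the core of compound 2 and differs by 2-methoxyphenyl in place of 3,4-dimethylphenyl on a double-bonded chain carbon bound to a double-bonded chain carbon. Among the compounds with values here, no measured pair shows this change, so the size of its step in this assay is open; the two rings are alike in size, and no shift beyond the scatter is expected. Compound 3 is expected to give about 10000 nM, within 4000 nM to 25000 nM, a step of no change at the digits printed from compound 2 to compound 3 (within the scatter) that is expected to stay within the scatter.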

Compound 3, half-maximal inhibitory concentration: 14700 nM
For compound 3 the middle estimate is 1.5-fold (0.17 log units) below the measured one, and the stated range covers the measured number.
By their numbers in this assay, from the lowest: compounds 2, 3 and 1 (each within the scatter of the next, the first and the last beyond it).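

Within the data shown here, this is the first pair that differs in one place, and in this assay the exchange of 3,4-dimethylphenyl for 2-methoxyphenyl gives a 1.5-fold higher number from compound 2 to compound 3 (0.17 log units; within the scatter). At this position, then, a ring with one hydrogen-bond acceptor reads the same as a ring with none, within the scatter. Nothing available explains this result. Still open, as far as these compounds go, is whether a ring carrying an amine or a carboxylic acid at this position would move the number beyond the scatter. Also open, from the compounds shown here alone, is whether the same exchange would give a similar step on the core of compound 1.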